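Chloro Added to the Phenyl Ring of Compound 1

The compounds below may be only part of what the source reports. "The series", "measured", "known", "first", "only" and "open" are said of these compounds alone.

Compound 1 `CC1=CC[C@H](C(C)(C)NC(=S)N/N=C/c2ccccc2)CC1` was tested in a functional assay on U-251 cells (Homo sapiens) for inhibition, read by sulforhodamine B assay, with a stated time of 48 h (on this read-out lower numbers stand for stronger inhibition of growth and higher numbers for weaker inhibition of growth), where compound 1 gives 71400 nM. Within the data shown here, of the two plain numbers known, compound 1 stands level with its one neighbour: compound 2 `COc1ccc(/C=N/NC(=S)NC(C)(C)[C@H]2CC=C(C)CC2)cc1`, which carries a methoxy group, gives 71900 nM in this assay, and the step of a 1.0-fold higher number from compound 1 to compound 2 (0.00 log units; within the scatter) shows no real change. Compound 3 `CC1=CC[C@H](C(C)(C)NC(=S)N/N=C/c2ccc(F)cc2)CC1`, which carries a fluoro group, reached only the limit of this assay and gives > 100000 nM. The step of an at least 1.4-fold higher number from compound 1 to compound 3 (0.14 log units; that floor lies within the scatter) is therefore known only as a floor.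

Compound 4 `CC1=CC[C@H](C(C)(C)NC(=S)N/N=C/c2ccccc2Cl)CC1` differs from compound 1 by chloro in place of hydrogen on an aromatic carbon. The two measured steps that place a small group on the same ring, a 1.0-fold higher number from compound 1 to compound 2 (0.00 log units; within the scatter) and an at least 1.4-fold higher number from compound 1 to compound 3 (0.14 log units; that floor lies within the scatter), both sit within the scatter or only at its edge, so no step beyond the scatter is expected in this assay, and if anything a slightly higher number. Compound 4 is thus expected to give about 85000 nM, between 40000 nM and 180000 nM, an expected step of a 1.2-fold higher number from compound 1 to compound 4 (0.08 log units; within the scatter). Because one of the three values is the limit recorded in the limit of > 100000 nM in this assay, at which 1 of the 3 values shown sits, a limit is also a likely outcome for compound 4.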

Compound 4, concentration for total growth inhibition: > 100000 nM
Compound 4 gave a limit, no number (the forecaster's own chance of this, stated with the estimate: 35%); middle value at least 1.1-fold (0.07 log units) away from the limit.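

Chloro on an aromatic carbon, ortho to a large group, gives an at least 1.4-fold higher number from compound 1 to compound 4 (0.14 log units; that floor lies within the scatter), and the comparison with the methoxy compound gives an at least 1.3-fold higher number from compound 2 to compound 4 (0.14 log units; that floor lies within the scatter); both are only floors, so either true step could be larger. The step between compound 3 and compound 4 cannot be read, since both are limits, but with this third ring change, still none has brought the number down beyond the scatter. The result for compound 4 is a limit, and limits now make up a large share of this small series in this assay: the limit of > 100000 nM in this assay, at which 2 of the 4 values shown sit.

Going by these compounds, how far past the limit compound 3 and compound 4 really lie remains unknown. Also open, on these data alone, is whether an amine or a carboxylic acid on this ring would bring the number down.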